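This account rests on a few compounds, and the source may have more. Where it says the series, first, only, none or still open, it means among the compounds named here.

Of the compounds shown here, three built on a shared core have been measured in a functional assay on the whole organism (strain Swiss albino) for inhibition, with Mus musculus as the target, with stated times of 10 min, 5 min and 20 min; a higher number here means that more compound is needed for the effect, a lower number that less compound is needed. Compound 1 `O=C(CN1CCN(c2cccc(C(F)(F)F)c2)CC1)N(c1ccccc1)c1ccccc1` gives 21.3 mg/kg, compound 2 `COc1ccccc1N1CCN(CC(=O)N(c2ccccc2)c2ccccc2)CC1` gives 8.2 mg/kg, and compound 3 `O=C(CN1CCN(c2cccc(Cl)c2)CC1)N(c1ccccc1)c1ccccc1` gives 16.5 mg/kg. Compound 2 has the lowest of the three numbers: the step of a 2.0-fold higher number from compound 2 to compound 3 (0.30 log units; within the scatter) is within the scatter, whereas a 2.6-fold lower number from compound 1 to compound 2 (0.41 log units; beyond the scatter) lies beyond it.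

The unmeasured compound 4 `O=C(CN1CCN(c2ccc(F)cc2)CC1)N(c1ccccc1)c1ccccc1` differs from compound 2 by 4-fluorophenyl in place of 2-methoxyphenyl on an amine nitrogen in a ring. Among the compounds with values here, two measured steps bear on this change. The first is a 2.0-fold higher number from compound 2 to compound 3 (0.30 log units; within the scatter), in which a 3-chlorophenyl took the place of the 2-methoxyphenyl on the same ring nitrogen. The second is a 1.3-fold lower number from compound 1 to compound 3 (0.11 log units; within the scatter), in which chloro replaced trifluoromethyl on the phenyl carried by that nitrogen. Both steps are within the scatter, so exchanging the 2-methoxyphenyl for a 4-fluorophenyl would be expected to produce, in this assay, no more than a modest move toward a higher number, and possibly none beyond the scatter.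

Compound 4 is therefore estimated at 13 mg/kg, with a range from 6 mg/kg to 28 mg/kg. That estimate corresponds to an expected step of a 1.6-fold higher number from compound 2 to compound 4 (0.20 log units; within the scatter), small enough that it may stay inside the scatter.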

Compound 4, dose for half-maximal effect: 13.4 mg/kg
Estimate against measurement, compound 4: 1.0-fold (0.01 log units) below; low and high end bracket the measured number.
By their numbers in this assay, from the lowest: compounds 2, 4, 3 and 1 (each within the scatter of the next, the first and the last beyond it).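

In this assay, within the data shown here, the exchange of 2-methoxyphenyl for 4-fluorophenyl on the amine nitrogen in the ring gives a 1.6-fold higher number from compound 2 to compound 4 (0.21 log units; within the scatter) and so stays within the scatter, even though the hydrogen-bond acceptor counted in the leaving group has no counterpart in the entering one. The other two new steps also stay within it, with a 1.2-fold lower number from compound 3 to compound 4 (0.09 log units; within the scatter) and a 1.6-fold lower number from compound 1 to compound 4 (0.20 log units; within the scatter) as the readings, so the one gap beyond the scatter, a 2.6-fold lower number from compound 1 to compound 2 (0.41 log units; beyond the scatter) as its reading, now has between its ends a compound that neither end can be told apart from, and the four aryl groups at this nitrogen form a single narrow set with only compound 1 and compound 2 separated. No measurement here offers an explanation for these small steps.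

Each exchange changes both the substituent and its place on the phenyl ring, so the effect of either alone remains unresolved. From the compounds shown here alone, it also remains open whether an unsubstituted phenyl, or a phenyl carrying an amine or a carboxylic acid, would move the number beyond the scatter from compound 4.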